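Urea aryl change on the shared core: dichloro to trifluoromethyl

The compounds below may be only part of what the source reports. "The series", "measured", "known", "first", "only" and "open" are said of these compounds alone.

Compound 3 `COc1cc(Cl)cc(-c2nn(-c3cccc(NC(=O)Nc4ccc(Cl)c(Cl)c4)c3)cc2-c2ccncc2)c1` gives 70% in a functional assay on SF-295 cells (Homo sapiens) for inhibition, read by sulforhodamine B assay, with a stated time of 48 h, tested at 1 uM; on this read-out higher numbers stand for a weaker effect at the one concentration tested and lower numbers for a stronger effect. On the numbers shown it stands highest of the three, which on this read-out is the weakest effect at the single concentration: compound 1 `COc1cc(Cl)cc(-c2nn(-c3cccc(NC(=O)Nc4ccc(Cl)c(C(F)(F)F)c4)c3)cc2-c2ccncc2)c1` gives 31%, and compound 2 `COc1cc(Cl)cc(-c2nn(-c3cccc(NC(=O)Nc4cc(C(F)(F)F)cc(C(F)(F)F)c4)c3)cc2-c2ccncc2)c1` gives 12%. Within the data shown here, the only single-point step measured so far, chloro in place of trifluoromethyl on an aromatic carbon, reads a number 39 percentage points higher from compound 1 to compound 3 (beyond the scatter).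

Compound 4 `COc1cc(Cl)cc(-c2nn(-c3cccc(NC(=O)Nc4cccc(C(F)(F)F)c4)c3)cc2-c2ccncc2)c1` differs from compound 3 by 3-(trifluoromethyl)phenyl in place of 3,4-dichlorophenyl on an amide-type nitrogen. Among the measured compounds shown here, no measured step matches this change exactly. The step of a number 39 percentage points higher from compound 1 to compound 3 (beyond the scatter) bears on it in the reverse sense: exchanging a trifluoromethyl for chloro raised the number by a large amount, so a return to a trifluoromethyl-bearing ring is expected to lower it. Compound 1 and compound 2, both carrying a trifluoromethyl on this ring, show the lower values of the set. On that basis a downward step beyond the scatter is expected, a number 30 percentage points lower from compound 3 to compound 4 (beyond the scatter), though with one trifluoromethyl and no chlorine on the entering ring its size is uncertain. Compound 4 is estimated at 40%, within a range from 20% to 65%.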

Compound 4, a percentage reported as activity, at one concentration (the size of the read-out at that concentration, not a potency): 45%
Compound 4: the middle estimate sits 5 percentage points below what was measured; measured number inside the range.
By their numbers in this assay, from the lowest: compound 2; then compound 1; then compound 4; then compound 3.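

Compound 4 isolates a single trifluoromethyl on the ring at this amide-type nitrogen, and this shows that added groups on that ring can matter in both forms. In this assay hydrogen in place of chloro reads a number 14 percentage points higher from compound 1 to compound 4 (beyond the scatter) as a modest step, and hydrogen in place of trifluoromethyl reads a number 33 percentage points higher from compound 2 to compound 4 (beyond the scatter) as a large one, so among compound 1, compound 2 and compound 4 a second group on the 3-(trifluoromethyl)phenyl ring goes with a lower number. Compound 3 goes against any reading by group count alone: exchanging 3,4-dichlorophenyl for 3-(trifluoromethyl)phenyl gives a number 25 percentage points lower from compound 3 to compound 4 (beyond the scatter) as a modest step, although the entering ring carries one group and the leaving ring two, and nothing shown gives a measured reason for any of these differences.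

Still open, as far as these compounds go, is how much of the effect belongs to the trifluoromethyl itself, which a phenyl ring with no added group, or one bearing a single chloro, a methoxy or a nitrile, on the same nitrogen would help to separate. With one concentration in one cell line, the order of these four compounds also says nothing yet about potency.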